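Series notes: ester to acid on the aryloxy chain

This account rests on a few compounds, and the source may have more. Where it says the series, first, only, none or still open, it means among the compounds named here.

Compound 1 `COCOc1ccc(CN(Cc2ccc(C(C)(C)C)cc2)Cc2cc3cc(C)ccc3[nH]c2=O)cc1` gives 6400 nM in a toxicity assay on MDCK cells (Canis lupus familiaris) for cytotoxicity, read by crystal violet staining, with a stated time of 48 h; on this read-out higher numbers stand for lower toxicity in this test and lower numbers for higher toxicity in this test. Compound 2 `Cc1ccc2[nH]c(=O)c(CN(Cc3ccc(OCC(=O)OC(C)(C)C)cc3)Cc3ccc(C(C)(C)C)cc3)cc2c1` differs at the chain on the aryloxy oxygen, and in this assay compound 2 reports only the limit > 10000 nM, which is a boundary of the test and not a number. The step of an at least 1.5-fold higher number from compound 1 to compound 2 (0.19 log units; that floor lies within the scatter) is therefore open-ended, as shown by the limit of > 10000 nM in this assay, at which 1 of the 2 values shown sits. Compound 3 `Cc1ccc2[nH]c(=O)c(CN(Cc3ccc(OCC(=O)O)cc3)Cc3ccc(C(C)(C)C)cc3)cc2c1` is the next member; its change from compound 2 is hydrogen in place of tert-butyl on an oxygen next to a carbonyl group. Going by the values given here, the only measured step touches the same chain but no carboxy group, so it bears on the position rather than on this exact change; it shows no worsening of the read-out there. Compound 3 is expected to stay near compound 2, with a step that the limit leaves unreadable from compound 2 to compound 3 not beyond the scatter. The estimate for compound 3 is 12000 nM, with a range of 5000 nM to 30000 nM.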

Compound 3, half-maximal cytotoxic concentration: > 10000 nM
Compound 3: only a limit was reported (the forecaster's own chance of this, stated with the estimate: 60%); the middle value is on the limit's open side.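

In this assay, the carboxy group on the chain ends at the same limit as the tert-butoxycarbonyl group, so neither end of the chain gives a measured number: the limit of > 10000 nM in this assay, at which 2 of the 3 values shown sit.

Carboxy in place of methoxy gives an at least 1.5-fold higher number from compound 1 to compound 3 (0.19 log units; that floor lies within the scatter), which is open-ended and does not by itself separate the two ends of the chain. Going by these compounds alone, the step between compound 2 and compound 3 cannot be read, so the data show only that removing the tert-butyl group does not bring the read-out back to a measured number.

As far as these compounds go, how far compound 2 and compound 3 lie past the limit stays open. Also open, from the compounds shown here alone, is whether an amine or a primary amide on the same chain would give a measured number in this assay.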